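The source may hold more compounds than are shown below. What is called first, only, known or untested is meant among the compounds shown, and "the series" means these compounds.

Measured so far:
compound 1, `O=c1c2cc([N+](=O)[O-])ccc2n(CCO)n1Cc1ccccc1`: > 256000 nM
compound 2, `O=c1c2cc([N+](=O)[O-])ccc2n(CCCO)n1Cc1ccccc1`: > 256000 nM
compound 3, `O=[N+]([O-])c1ccc2nn(Cc3ccccc3)c(OCCO)c2c1`: > 256000 nM

In an ADME assay on L929 cells (Mus musculus) for cytotoxicity, read by resazurin assay, with a stated time of 48 h (on this read-out lower numbers stand for higher toxicity in this test and higher numbers for lower toxicity in this test), compound 1 gives > 256000 nM, which is a limit of the assay rather than a number. Compound 2 likewise gives > 256000 nM, again only a limit. Compound 3 gives > 256000 nM, also a limit. Compound 1 and compound 2 differ by hydroxymethyl in place of hydroxy on a saturated chain carbon, two bonds along the chain from an aromatic nitrogen, and the two limits leave the step that the two limits leave unreadable from compound 1 to compound 2. Compound 4, `O=[N+]([O-])c1ccc2nn(Cc3ccccc3)c(OCCCO)c2c1`, differs from compound 3 by hydroxymethyl in place of hydroxy on a saturated chain carbon, two bonds along the chain from an oxygen on an aromatic ring. For the measured compounds named here, this is the same kind of change as the one from compound 1 to compound 2, but its place is two bonds along the chain from an oxygen on an aromatic ring rather than from an aromatic nitrogen, and the difference between the core of compound 1 and the core of compound 3 is not broken down here. Because all three values sit at the limit of > 256000 nM in this assay, at which 3 of the 3 values shown sit, the step is expected to be small, estimated as a step that the limit leaves unreadable from compound 3 to compound 4 in this assay. Compound 4 is therefore expected to give about 400000 nM, most likely once more reported only as a limit.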

Compound 4, concentration lethal to 50% of the cells: > 256000 nM
Compound 4 was reported as a limit; the forecaster's own chance of this, stated with the estimate: 85%; the middle value lies beyond the limit too.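

Compound 3 and compound 4 are both reported only as limits, and the step between them cannot be read. The compounds shown leave open what any actual value is and whether either chain change alters toxicity in this test at all: the limit of > 256000 nM in this assay, at which 4 of the 4 values shown sit.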